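This account rests on a few compounds, and the source may have more. Where it says the series, first, only, none or still open, it means among the compounds named here.

Compound 1 `Nc1nn(C(=O)Nc2ccc(Cc3ccccc3)cc2)c2ccccc12` and compound 2 `Nc1nn(C(=O)Nc2ccc(Cc3ccccc3)cc2)c2ccc(Cl)cc12` share one core and one side chain, and differ only at one aromatic carbon of the fused ring. In a functional assay on Malme-3M cells (Homo sapiens) for antiproliferative activity, read by sulforhodamine B assay, with a stated time of 48 h (a lower number here means a stronger inhibitor of growth, a higher number a weaker inhibitor of growth), compound 1 gives 64100 nM. In this assay compound 2 gives 54800 nM. Within the data shown here, the step of a 1.2-fold lower number from compound 1 to compound 2 (0.07 log units; within the scatter) is the only step measured so far. On these two numbers compound 2 stands with the lower one, but its gap to compound 1 is within the scatter, so nothing can be said about an order between the two.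

Compound 3 `Nc1ccc2c(c1)c(N)nn2C(=O)Nc1ccc(Cc2ccccc2)cc1` is the next compound. It carries amino in place of chloro on an aromatic carbon. Among the measured compounds shown here, the one measured step, a 1.2-fold lower number from compound 1 to compound 2 (0.07 log units; within the scatter), concerns the same position and was within the scatter; it says nothing directly about an amino group at this position, since no amino-bearing compound has yet been measured. The reasonable expectation is therefore that compound 3 stays close to compound 2, with a step of a 1.1-fold higher number from compound 2 to compound 3 (0.04 log units; within the scatter) that is expected to lie within the scatter. Compound 3 is accordingly estimated at 60000 nM in this assay, with a range from 25000 nM to 150000 nM.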

Compound 3, concentration for total growth inhibition: 89800 nM
For compound 3 the middle estimate is 1.5-fold (0.18 log units) below the measured one, within the range that was stated.
By their numbers in this assay, from the lowest: compounds 2, 1 and 3 (each within the scatter of the next).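

With compound 3 this aromatic carbon has carried hydrogen, chloro and amino, and in this assay the amino group gives a 1.6-fold higher number from compound 2 to compound 3 (0.21 log units; within the scatter) and a 1.4-fold higher number from compound 1 to compound 3 (0.15 log units; within the scatter) so that neither of the new steps leaves the scatter. The earlier pair showed this only for chloro in place of hydrogen, whereas it now also holds for amino, which unlike chloro is counted as a hydrogen-bond donor and acceptor, and the three compounds cannot be put in any order. No information is available here that bears on these results.

What the compounds shown leave open is whether any group on this aromatic carbon can move the number beyond the scatter, as a carboxylic acid, a methoxy group or a longer chain might or might not do. Among these compounds, they also leave open whether the same holds on the other aromatic carbons of the shared core, or with a side chain other than the one that all three compounds carry.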